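From phenoxy to benzyl on a shared core

The compounds below may be only part of what the source reports. "The series", "measured", "known", "first", "only" and "open" are said of these compounds alone.

Measured so far in a physicochemical assay for solubility, measured as kinetic solubility; on this read-out higher numbers stand for higher solubility and lower numbers for lower solubility:
Compound 1 `O=C(Nc1ccc(Cl)cc1)C1CCCN(C(=O)c2cccc(-c3cccs3)c2)C1` gives 1.36 ug/mL
Compound 2 `O=C(Nc1cccc(Oc2ccccc2)c1)C1CCCN(C(=O)c2cc(C(F)(F)F)cc(C(F)(F)F)c2)C1` gives 3.22 ug/mL

Of these two numbers, compound 2 holds the higher one. In this assay compound 2 stands at 3.22 ug/mL and compound 1 at 1.36 ug/mL, a gap beyond the usual scatter. The two compounds differ in more than one place, so that gap says nothing about any single change.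

Compound 3 `O=C(Nc1cccc(Cc2ccccc2)c1)C1CCCN(C(=O)c2cc(C(F)(F)F)cc(C(F)(F)F)c2)C1` has not yet been measured. It carries benzyl in place of phenoxy on an aromatic carbon, and the rest of compound 2 stays as it is benzyl in place of phenoxy on an aromatic carbon. Within the data shown here, the data hold no measured step between compounds that differ in only one place, so this change has no direct precedent here. The estimate therefore starts from compound 2 at 3.22 ug/mL and moves it only slightly downward. The expected step of a 1.2-fold lower number from compound 2 to compound 3 (0.09 log units; within the scatter) is small and not beyond the scatter. For compound 3 the estimated value is 2.6 ug/mL (1 ug/mL to 6.5 ug/mL) .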

Compound 3, solubility: 1.89 ug/mL
Estimate against measurement, compound 3: 1.4-fold (0.14 log units) above; the measured number falls inside the stated range.
By their numbers in this assay, from the lowest: compounds 1, 3 and 2 (each within the scatter of the next, the first and the last beyond it).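

In this assay, among these compounds, this pair gives the only reading of a single change: benzyl in place of phenoxy on an aromatic carbon, meta to a large group, is a 1.7-fold lower number from compound 2 to compound 3 (0.23 log units; within the scatter), so at this place on the shared core the exchange stays inside what repeated measurements would show. The two groups match in heavy-atom total and in their six-membered aromatic ring of carbon only, and they differ in phenoxy's oxygen and the hydrogen-bond acceptor it carries, so in this pair that difference does not separate the two compounds beyond the scatter. Nothing measured here explains the result or bears on what either group does to the read-out.

On these data alone, this is one step at one place, read with the bis(trifluoromethyl)-substituted benzoyl end held fixed, so it remains open whether the same exchange would read the same way with another group at that end of the molecule. As far as these compounds go, it also remains open whether an amine or a carboxylic acid at this place would move the number beyond the scatter, as neither phenoxy nor benzyl has done so far.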